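Swapping benzyl for an open chain on compound 3

The compounds below may be only part of what the source reports. "The series", "measured", "known", "first", "only" and "open" are said of these compounds alone.

Measured in a functional assay on EOL1 cells (Homo sapiens) for inhibition, read by fluorescence, with a stated time of 72 h; on this read-out lower numbers stand for stronger inhibition of growth and higher numbers for weaker inhibition of growth:
- compound 1 `CC(C)CCn1cnc2c(Nc3cccc(Cl)c3)nc(N[C@H]3CC[C@H](N)CC3)nc21`: 60 nM
- compound 2 `CCCCn1cnc2c(Nc3cccc(Cl)c3)nc(N[C@H]3CC[C@H](N)CC3)nc21`: 160 nM
- compound 3 `N[C@H]1CC[C@H](Nc2nc(Nc3cccc(Cl)c3)c3ncn(Cc4ccccc4)c3n2)CC1`: 380 nM

Among these three, compound 3 has the highest number, 380 nM, and so shows the weakest inhibition of growth. Compound 4 `CC(C)=CCC/C(C)=C/Cn1cnc2c(Nc3cccc(Cl)c3)nc(N[C@H]3CC[C@H](N)CC3)nc21` keeps the shared core but changes one group: 2,6-dimethylhepta-1,5-dien-1-yl in place of phenyl on a saturated chain carbon bound to an aromatic nitrogen. This is 2,6-dimethylhepta-1,5-dien-1-yl in place of phenyl on a saturated chain carbon bound to an aromatic nitrogen, or benzyl to 3,7-dimethylocta-2,6-dien-1-yl.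

The closest evidence comes from the two measured steps that put phenyl in place of an open chain at this carbon: a 2.4-fold higher number from compound 2 to compound 3 (0.38 log units; beyond the scatter) and a 6.3-fold higher number from compound 1 to compound 3 (0.80 log units; beyond the scatter). Both are modest. The chain can also matter in its details, as a 2.7-fold higher number from compound 1 to compound 2 (0.43 log units; beyond the scatter) shows. Within the data shown here, no measured compound carries a chain as large as the one in compound 4, so this comparison is uncertain. A modest drop in the number is therefore expected, rather than no change.

The estimated step is a 3.2-fold lower number from compound 3 to compound 4 (0.50 log units; beyond the scatter).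

In this assay, the estimate for compound 4 is 120 nM, with an expected range of 35 nM to 400 nM.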

Compound 4, concentration for 50% growth inhibition: 590 nM
Beside the measured number, compound 4's estimate is 4.9-fold (0.69 log units) below it, and the stated range ends below it.
By their numbers in this assay, from the lowest: compound 1; then compound 2; then compounds 3 and 4 (each within the scatter of the next).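

In this assay, the step of a 1.6-fold higher number from compound 3 to compound 4 (0.19 log units; within the scatter) shows that replacing benzyl with 3,7-dimethylocta-2,6-dien-1-yl does not by itself bring the lower numbers seen with the open chains of compound 1 and compound 2. Having an open chain at this position is therefore not enough, since the steps of a 3.7-fold higher number from compound 2 to compound 4 (0.57 log units; beyond the scatter) and a 9.8-fold higher number from compound 1 to compound 4 (0.99 log units; beyond the scatter) separate this larger chain from those two. No measurement shown here accounts for this result.

A hexyl chain could show how the number changes with chain size between compound 1 and compound 4, while the fully saturated 3,7-dimethyloctyl chain would separate the effect of chain size from that of the two double bonds. Going by these compounds, whether an amine at the end of the chain would be tolerated also remains open.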